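Chloro and N-phenyl changes on a fused lactam core

The compounds below may be only part of what the source reports. "The series", "measured", "known", "first", "only" and "open" are said of these compounds alone.

Measured compounds:
compound 1, `Cc1nn(C)c2c1C(c1ccccc1)=NCC(=O)N2`, 16 mg/kg
compound 2, `Cc1nn(C)c2c1C(c1cccc(Cl)c1)=NCC(=O)N2`, > 500 mg/kg (a limit)
compound 3, `Cc1nn(-c2ccccc2)c2c1C(c1ccccc1)=NCC(=O)N2`, > 500 mg/kg (a limit)

All three were tested in a functional assay on the whole organism with Rattus norvegicus as the target; on this read-out higher numbers stand for an effect only at larger amounts of compound and lower numbers for an effect already at smaller amounts. Compound 1 gives 16 mg/kg. For compound 2 the assay reports only a limit, > 500 mg/kg. For compound 3 the assay likewise reports only a limit, > 500 mg/kg. Compound 2 differs from compound 1 by chloro in place of hydrogen on an aromatic carbon, and this gave an at least 31-fold higher number from compound 1 to compound 2 (1.49 log units; beyond the scatter). Compound 3 differs from compound 1 by phenyl in place of methyl on an aromatic nitrogen, and this gave an at least 31-fold higher number from compound 1 to compound 3 (1.49 log units; beyond the scatter). Both changes thus carry the read-out to the limit of > 500 mg/kg in this assay, at which 2 of the 3 values shown sit.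

Compound 4, `Cc1nn(-c2ccccc2)c2c1C(c1ccccc1Cl)=NCC(=O)N2`, has not yet been measured. It differs from compound 3 by chloro in place of hydrogen on an aromatic carbon. This is the same kind of change as that from compound 1 to compound 2, but the place differs: in compound 2 the chloro sits meta to a large group, in compound 4 ortho to a large group. Compound 3 already sits at the limit, so the step to compound 4 cannot be fully resolved. Compound 4 is expected to give 500 mg/kg, with the range 150 mg/kg to 2000 mg/kg, an expected step of a number no higher from compound 3 to compound 4 (the limit leaves the size open). That expectation rests on compound 3, which gives only the limit > 500 mg/kg. It rests too on the step of an at least 31-fold higher number from compound 1 to compound 2 (1.49 log units; beyond the scatter) made by the same kind of change.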

Compound 4, minimum effective dose: 500 mg/kg
Beside the measured number, compound 4's estimate shows no gap at the digits printed; low and high end bracket the measured number.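

In this assay the change from hydrogen to chloro does not carry over as one fixed step from the core of compound 1 to the core of compound 3: the same change on two cores in this assay, an at least 31-fold higher number (1.49 log units; beyond the scatter) from compound 1 to compound 2 and a number no higher (the limit leaves the size open) from compound 3 to compound 4, at least 31-fold (1.49 log units) apart, beyond the scatter of two such steps. This does not show that the core alone decides the outcome, for the chloro of compound 4 sits ortho to a large group and that of compound 2 sits elsewhere, and the two steps shown do not separate core from place. The new step reads only as a number no higher from compound 3 to compound 4 (the limit leaves the size open), and how far the chloro change moves the read-out on this core cannot be read.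

The compounds shown leave open how a chloro ortho to a large group would read on the core of compound 1, which would set place apart from core, and whether an ethyl group in place of the phenyl on the aromatic nitrogen would stay close to the value of compound 1, 16 mg/kg. Also open, from the compounds shown here alone, is how a fluoro or a methoxy group in place of the chloro, or an amine on the same ring, would read in this assay.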